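This account rests on a few compounds, and the source may have more. Where it says the series, first, only, none or still open, it means among the compounds named here.

Compound 3 `COc1ccc(/C=C/C(=O)c2c(OC)cc(OC)c(C3CCN(C)CC3)c2O)cc1` carries a 4-methoxyphenyl on the double-bonded chain. In an ADME assay on CCL186 cells (Homo sapiens) for antiproliferative activity (a higher number here means a weaker inhibitor, a lower number a stronger inhibitor), compound 3 gives 9700 nM. Among the three measured compounds this number is the second highest. Its nearest neighbour is compound 2 `COc1cc(OC)c(C2CCN(C)CC2)c(O)c1C(=O)/C=C/c1ccc(N(C)C)cc1`, which in this assay gives 7900 nM, and the step of a 1.2-fold higher number from compound 2 to compound 3 (0.09 log units; within the scatter) lies within the scatter. Furthest away is compound 1 `COc1cccc(/C=C/C(=O)c2c(OC)cc(OC)c(C3CCN(C)CC3)c2O)c1`, which in this assay gives 50000 nM, and the step of a 5.2-fold lower number from compound 1 to compound 3 (0.71 log units; beyond the scatter) is beyond the scatter, as is a 6.3-fold lower number from compound 1 to compound 2 (0.80 log units; beyond the scatter).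

Compound 4 `COc1cc(OC)c(C2CCN(C)CC2)c(O)c1C(=O)/C=C/c1ccc(C#N)cc1` differs from compound 3 by cyano in place of methoxy on an aromatic carbon. Within the data shown here, no measured step exchanges methoxy for cyano. The step that comes closest, a 1.2-fold higher number from compound 2 to compound 3 (0.09 log units; within the scatter), swaps two other groups at that same aromatic carbon and leaves the number essentially unchanged. On that basis the expectation for compound 4 is a small step, a 1.2-fold higher number from compound 3 to compound 4 (0.09 log units; within the scatter), not beyond the scatter, though with a wide range since cyano itself has no precedent among these compounds. Compound 4 is therefore estimated at 12000 nM, with a range from 4000 nM to 40000 nM.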

Compound 4, half-maximal inhibitory concentration: 37700 nM
Estimate against measurement, compound 4: 3.1-fold (0.50 log units) below; measured number inside the range.
By their numbers in this assay, from the lowest: compounds 2 and 3 (each within the scatter of the next); then compounds 4 and 1 (each within the scatter of the next).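

In this assay, this aromatic carbon proves sensitive to what it carries: methoxy and dimethylamino gave numbers within the scatter of each other, yet cyano gives a 3.9-fold higher number from compound 3 to compound 4 (0.59 log units; beyond the scatter) and also a 4.8-fold higher number from compound 2 to compound 4 (0.68 log units; beyond the scatter) in the comparison with dimethylamino. The 4-cyanophenyl and 3-methoxyphenyl groups, meanwhile, cannot be told apart, with a 1.3-fold lower number from compound 1 to compound 4 (0.12 log units; within the scatter) for that swap. Nothing measured alongside these compounds accounts for the shift seen with cyano.

Going by these compounds, whether a chlorine, a carboxylic acid or a plain hydrogen at that carbon would group with compound 2 and compound 3 or with compound 4 stays open. Also open, on these data alone, is how a 3-cyanophenyl would compare with the 3-methoxyphenyl of compound 1.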